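Tetrazole for oxadiazole in a bradykinin B1 antagonist series

The source may hold more compounds than are shown below. What is called first, only, known or untested is meant among the compounds shown, and "the series" means these compounds.

Compound 1 `Cc1noc(-c2c(F)cccc2-c2ccc([C@@H](C)Nc3nccc(Cl)c3NC(=O)CC#N)cc2)n1` and compound 2 `COC(=O)c1c(Cl)cccc1-c1ccc([C@@H](C)Nc2nccc(Cl)c2NC(=O)CC#N)cc1` share one core and differ in the groups attached to it. In a functional assay with B1 bradykinin receptor (Oryctolagus cuniculus) as the target, read by FLIPR (on this read-out higher numbers stand for weaker inhibition and lower numbers for stronger inhibition), compound 1 gives 12.3 nM, the higher of the two numbers. Compound 2 gives 7.2 nM in this assay, and the two values lie within the scatter of each other, so nothing can be said about which is the more potent. Compound 3 `C[C@@H](Nc1nccc(Cl)c1NC(=O)CC#N)c1ccc(-c2cccc(F)c2-c2nnn(C)n2)cc1` has not yet been measured. It differs from compound 1 in 2-methyl-2H-tetrazol-5-yl in place of 3-methyl-1,2,4-oxadiazol-5-yl on an aromatic carbon. Within the data shown here, no step between measured compounds tracks this exchange, so the two measured numbers give no direction for it; both are close, which suggests that this part of the molecule tolerates variation. Compound 3 is therefore expected to show a step of a 1.0-fold lower number from compound 1 to compound 3 (0.01 log units; within the scatter) from compound 1 that stays within the scatter. On that basis compound 3 is estimated at 12 nM in this assay, with a likely range from 5 nM to 30 nM.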

Compound 3, half-maximal inhibitory concentration: 3.9 nM
Estimate against measurement, compound 3: 3.1-fold (0.49 log units) above, outside the stated range (below it).
By their numbers in this assay, from the lowest: compounds 3, 2 and 1 (each within the scatter of the next, the first and the last beyond it).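

In this assay, 2-methyl-2H-tetrazol-5-yl in place of 3-methyl-1,2,4-oxadiazol-5-yl gives a 3.2-fold lower number from compound 1 to compound 3 (0.50 log units; beyond the scatter) and so shows that this position, ortho to a fluoro group, responds modestly to this exchange. The change keeps the count of 6 heavy atoms and the absence of net charge, and it replaces a ring of 3 carbon, 2 nitrogen and 1 oxygen atoms with one of 2 carbon and 4 nitrogen atoms, so the number can move beyond the scatter with those counts held. No measurement shown accounts for the step.

This single exchange leaves open how a carboxylic acid or an amine would read at this position. It also leaves open whether the step would persist with a chloro group in place of the fluoro group.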